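The source may hold more compounds than are shown below. What is called first, only, known or untested is meant among the compounds shown, and "the series" means these compounds.

In a functional assay on KG-1 cells (Homo sapiens) for cytotoxicity, read by luminescence and CellTiter-Glo, with a stated time of 3 days (on this read-out lower numbers stand for stronger inhibition and higher numbers for weaker inhibition), compound 1 `O=C(Nc1cc(C(F)(F)F)cc(C(F)(F)F)c1)c1ccc(-c2ccccc2)cc1O` gives 860 nM. Compound 2 `O=C(Nc1cccc(C(F)(F)F)c1)c1cc(F)ccc1O` gives 1010 nM in this assay, and compound 3 `O=C(Nc1ccc(Cl)c(C(F)(F)F)c1)c1cc(F)ccc1O` gives 540 nM. Compound 1 and compound 2 rest on different cores, and the difference between the two cores is not broken down here. Compound 3 differs from compound 2 by chloro in place of hydrogen on an aromatic carbon, and that change brought a 1.9-fold lower number from compound 2 to compound 3 (0.27 log units; within the scatter). Compound 4 `O=C(Nc1cc(C(F)(F)F)cc(C(F)(F)F)c1)c1cc(Cl)c(-c2ccccc2)cc1O` has not yet been measured; it differs from compound 1 by chloro in place of hydrogen on an aromatic carbon. For the measured compounds named here, this is the same kind of change as the one from compound 2 to compound 3, but the surroundings differ: in compound 3 the new chloro group sits ortho to a trifluoromethyl group and para to a large group, while in compound 4 it sits ortho to a phenyl group, meta to a large group and para to a hydroxy group. The earlier step, a 1.9-fold lower number from compound 2 to compound 3 (0.27 log units; within the scatter), lay within the scatter. On that basis the step to compound 4 is expected to be of similar small size, a 1.4-fold lower number from compound 1 to compound 4 (0.16 log units; within the scatter). For compound 4 the expected value in this assay is 600 nM, with a likely range from 250 nM to 1500 nM.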

Compound 4, half-maximal inhibitory concentration: 430 nM
Estimate against measurement, compound 4: 1.4-fold (0.14 log units) above; the measured number falls inside the stated range.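

In this assay, chloro in place of hydrogen on an aromatic carbon brings a 2.0-fold lower number from compound 1 to compound 4 (0.30 log units; within the scatter). Set beside the same change on the other core, the new step does not stand apart from the earlier one: the same change on two cores in this assay, a 1.9-fold lower number (0.27 log units; within the scatter) from compound 2 to compound 3 and a 2.0-fold lower number (0.30 log units; within the scatter) from compound 1 to compound 4, 1.1-fold (0.03 log units) apart, within the scatter of two such steps. This shows that the change gave matching results on these two cores, but each step lies within the scatter on its own, so the data do not establish that chloro truly shifts the number, and two pairs cannot predict the step on a further core.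

The compounds shown leave open whether a different group on the carbon that carries chloro in compound 4, such as a methoxy group, an amine or a carboxylic acid, would give a number clearly apart from that of compound 1. They also leave open whether the chloro step would stay the same on a core that lacks the hydroxy group.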